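The source may report more compounds than this note shows. Statements on the series, on what has been measured and on what is new or still open speak of the compounds shown alone.

Measured in a functional assay on the whole organism (strain Sprague-Dawley) for inhibition, with Rattus norvegicus as the target, with a stated time of 10 min; a higher number here means that more compound is needed for the effect, a lower number that less compound is needed:
- compound 1 `CCOC(=O)c1cnc(-c2ccccc2Cl)[nH]c1=O`: 5 mg/kg
- compound 2 `CCOC(=O)c1cnc(-c2ccccc2O)[nH]c1=O`: 5 mg/kg
- compound 3 `CCOC(=O)c1cnc(-c2ccccc2OC)[nH]c1=O`: 10 mg/kg

At 10 mg/kg, compound 3 lies within the usual scatter of both other compounds. Compound 4 `CCCCOc1ccccc1-c1ncc(C(=O)OCC)c(=O)[nH]1` differs from it by one change: propyl in place of hydrogen on a saturated chain carbon bound to an oxygen on an aromatic ring. This is propyl in place of hydrogen on a saturated chain carbon bound to an oxygen on an aromatic ring, so methoxy becomes butoxy. The nearest evidence is a 2.0-fold higher number from compound 2 to compound 3 (0.30 log units; within the scatter), where a methyl was added on that oxygen. Changing the group itself gave a 2.0-fold higher number from compound 1 to compound 3 (0.30 log units; within the scatter). Neither step left the scatter, but no longer chain has been measured, so the range stays wide. The expected change is no change at the digits printed from compound 3 to compound 4 (within the scatter), with no shift beyond the scatter anticipated. For compound 4 the estimate is 10 mg/kg, with an expected range from 3 mg/kg to 30 mg/kg.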

Compound 4, dose for 50% inhibition: 0.5 mg/kg
Compound 4: the middle estimate sits 20-fold (1.30 log units) above what was measured, and the stated range ends above it.
By their numbers in this assay, from the lowest: compound 4; then compounds 1, 2 and 3 (each within the scatter of the next).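

In this assay the step from methoxy to butoxy gives a 20-fold lower number from compound 3 to compound 4 (1.30 log units; beyond the scatter) and so leaves the scatter, which the methyl added on the same oxygen did not do. Butoxy also stands apart from the other groups at this place, with a 10-fold lower number from compound 2 to compound 4 (1.00 log units; beyond the scatter) for hydroxy and a 10-fold lower number from compound 1 to compound 4 (1.00 log units; beyond the scatter) for chloro. The chain on this oxygen can therefore change the dose needed, and a lower number means less compound is needed.

On these data alone, whether ethoxy or propoxy lies between methoxy and butoxy, and whether a longer chain such as hexyloxy lowers the number further, stays open. Nothing in the data given explains this drop.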